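A few compounds are considered here, and "the series" means these few. Any claim that something is new, unique, unknown or untested is made for them only; others in the source may bear on it.

Going by the values given here, compound 2 `O=C(CCc1ccc(C(F)(F)F)cc1)Nc1ccc2nc(N3CC4CC3CO4)ccc2c1` holds the lowest of the two numbers known so far in an assay on isolated protein for displacement of a labelled ligand from melanin-concentrating hormone receptor 1 (Homo sapiens); a higher number here means a weaker inhibitor, a lower number a stronger inhibitor: compound 2 gives 13 nM, whereas compound 1 `CCCN(CCC)c1ccc2cc(NC(=O)CCc3ccc(C(F)(F)F)cc3)ccc2n1` gives 490 nM. Among the compounds with values here, the single recorded step, a 38-fold lower number from compound 1 to compound 2 (1.58 log units; beyond the scatter), accompanied the exchange of a chain with no ring for a group with two five-membered non-aromatic rings on the shared core. Compound 3 `O=C(CCc1ccc(C(F)(F)F)cc1)Nc1ccc2nc(N3CCC4(CCNC4)C3)ccc2c1` differs from compound 2 by a group of 9 heavy atoms (7 carbon, 2 nitrogen; 2 five-membered non-aromatic rings with 1 hetero atom each) in place of a group of 7 heavy atoms (5 carbon, 1 nitrogen, 1 oxygen; 2 five-membered non-aromatic rings with 1 hetero atom each), on an aromatic carbon; the entering group carries one hydrogen-bond donor where the leaving group had none. Within the data shown here, no measured step swaps one such two-ring group for another, so the bearing of the data is indirect: both groups in question resemble each other far more than either resembles the ring-free chain of compound 1. The step of a 1.3-fold lower number from compound 2 to compound 3 (0.11 log units; within the scatter) is therefore expected to remain within the scatter, perhaps leaning toward a lower number. Compound 3 is estimated at 10 nM, within 3 nM to 40 nM.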

Compound 3, half-maximal inhibitory concentration: 0.5 nM
Beside the measured number, compound 3's estimate is 20-fold (1.30 log units) above it; the whole stated range lies above it.
By their numbers in this assay, from the lowest: compound 3; then compound 2; then compound 1.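

In this assay, a 26-fold lower number from compound 2 to compound 3 (1.41 log units; beyond the scatter), so at this position, on an aromatic carbon next to the ring nitrogen, two groups that share 2 five-membered non-aromatic rings with 1 hetero atom each can still differ well beyond the scatter; the presence of these rings does not settle the number. Across the whole series, a 980-fold lower number from compound 1 to compound 3 (2.99 log units; beyond the scatter), a span that the step from the ring-free chain to the first two-ring group had only partly revealed. The entering group differs at once in size, in nitrogen for oxygen and in its 1 hydrogen-bond donor, and nothing available explains the gain.

The compounds shown do not separate these differences. A methyl group on the second ring nitrogen, or a piperazine in place of the two-ring group, would bear on which of them carries the step.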